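Fluoro for Chloro: Expected Inhibition of Compound 4

The compounds below may be only part of what the source reports. "The series", "measured", "known", "first", "only" and "open" are said of these compounds alone.

Compound 1, `CC1=C(C(=O)Nc2ccc([N+](=O)[O-])cc2)C(c2ccc(Br)cc2)N=C(SCc2ccc(Cl)cc2)N1`: 19.1%
Compound 2, `CC1=C(C(=O)Nc2ccc([N+](=O)[O-])cc2)C(c2ccc(Br)cc2)N=C(SCc2ccc(F)cc2)N1`: 17.5%
Compound 3, `CC1=C(C(=O)Nc2ccc([N+](=O)[O-])cc2)C(c2cccc([N+](=O)[O-])c2)N=C(SCc2ccc(Cl)cc2)N1`: 14.9%

Of the compounds shown here, three have been measured in a functional assay on the whole organism (artery, strain albino) with Rattus norvegicus as the target, with a stated time of 180 min, at a dose of 10 mg/kg by the oral route; on this read-out lower numbers stand for less inhibition and higher numbers for more inhibition at the one dose given (going by the name of the read-out). Compound 3 gives the lowest of the three numbers, but all three lie within the usual scatter of one another, so no order among them can be claimed.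

Compound 4, `CC1=C(C(=O)Nc2ccc([N+](=O)[O-])cc2)C(c2cccc([N+](=O)[O-])c2)N=C(SCc2ccc(F)cc2)N1`, has not yet been measured. It differs from compound 3 by fluoro in place of chloro on an aromatic carbon. The same change is already seen once among the measured compounds, going from compound 1 to compound 2, where it is described as fluoro in place of chloro on an aromatic carbon and produced a number 1.6 percentage points lower from compound 1 to compound 2 (within the scatter). The place of the change is the same in both pairs. The two cores differ in that (3-nitrophenyl in place of 4-bromophenyl on a saturated ring carbon), a change that gave a number 4.2 percentage points lower from compound 1 to compound 3 (within the scatter).

Within the data shown here, since the one earlier instance of this change stayed within the scatter, the step is expected to be a number 1.4 percentage points lower from compound 3 to compound 4 (within the scatter). Among the measured compounds shown here, this rests only on the single step from compound 1 to compound 2 and on the flat readings across the three measured compounds. Compound 4 is therefore estimated to give 13.5%, with a likely range from 5% to 22%.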

Compound 4, a percentage reported as inhibition, in the whole organism at one dose (the size of the read-out at that dose, not a potency): 17.5%
Compound 4: the middle estimate sits 4 percentage points below what was measured; the measured number falls inside the stated range.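

In this assay, fluoro in place of chloro on the core carrying 3-nitrophenyl gave a number 2.6 percentage points higher from compound 3 to compound 4 (within the scatter), and the two instances of this change do not differ by more than two such steps can scatter: the same change on two cores in this assay, a number 1.6 percentage points lower (within the scatter) from compound 1 to compound 2 and a number 2.6 percentage points higher (within the scatter) from compound 3 to compound 4, 4.2 percentage points apart, within the scatter of two such steps. The swap of 4-bromophenyl for 3-nitrophenyl, read on the fluoro compounds, gave no change at the digits printed from compound 2 to compound 4 (within the scatter), and it too reads alike on both cores: the same change on two cores in this assay, a number 4.2 percentage points lower (within the scatter) from compound 1 to compound 3 and no change at the digits printed (within the scatter) from compound 2 to compound 4, 4.2 percentage points apart, within the scatter of two such steps. This shows no dependence on the core for either change across these four compounds, but since every step stays within the scatter, it does not show that either change has a real effect, and it could not reveal a small dependence on the core.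

The compounds shown leave open how this assay would read with an amine or a carboxylic acid in place of the halogen, or with a longer alkyl chain in place of the benzyl group on sulfur. They also leave open whether any change in this series gives a step beyond the scatter.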